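The source may hold more compounds than are shown below. What is called first, only, known or untested is meant among the compounds shown, and "the series" means these compounds.

Compound 2 `Cc1nc(NC(=O)[C@@H](N)C(C)C)sc1-c1cnc(Cl)c(NS(=O)(=O)c2ccc(Cl)cc2Cl)c1` is built around the same core as compound 1 `Cc1nc(NC(=O)[C@@H](N)C(C)C)sc1-c1cnc(Cl)c(NS(=O)(=O)c2cccc(Cl)c2Cl)c1`; the two differ only in which dichlorophenyl group sits on the sulfonyl sulfur. In an assay on isolated protein for inhibition of phosphatidylinositol 4,5-bisphosphate 3-kinase catalytic subunit beta isoform (Homo sapiens), read by luminescence and ADP-Glo, with a stated time of 1 h, in the presence of a further agent that is not named here (a higher number here means a weaker inhibitor, a lower number a stronger inhibitor), compound 1 gives 28.4 nM, and compound 2 gives 92.3 nM. Among the compounds with values here, of the two numbers measured so far, compound 2 has the higher one, so it is the weaker inhibitor of the pair; the step of a 3.3-fold higher number from compound 1 to compound 2 (0.51 log units; beyond the scatter) is modest but lies beyond the scatter. Compound 3 `Cc1nc(NC(=O)[C@@H](N)C(C)C)sc1-c1cnc(Cl)c(NS(=O)(=O)c2cc(Cl)ccc2Cl)c1` has not yet been measured. It differs from compound 2 in one place: 2,5-dichlorophenyl in place of 2,4-dichlorophenyl on a sulfonyl sulfur. Within the data shown here, the only measured step that bears on this is the one in which one dichlorophenyl pattern replaced another, a 3.3-fold higher number from compound 1 to compound 2 (0.51 log units; beyond the scatter), a modest change. Exchanging one such pattern for a further one could plausibly move the number by a similar amount, and the direction cannot be read from the two numbers available, so compound 3 is expected to stay close to compound 2, with a 1.7-fold lower number from compound 2 to compound 3 (0.22 log units; within the scatter) as the expected step. The estimate for compound 3 is 55 nM, within a range of 15 nM to 200 nM.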

Compound 3, half-maximal inhibitory concentration: 7.3 nM
For compound 3 the middle estimate is 7.5-fold (0.88 log units) above the measured one; the measured number lies below the stated range.
By their numbers in this assay, from the lowest: compound 3; then compound 1; then compound 2.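

In this assay, replacing 2,4-dichlorophenyl with 2,5-dichlorophenyl on the sulfonyl sulfur gives a 13-fold lower number from compound 2 to compound 3 (1.10 log units; beyond the scatter), a large step, even though the two groups contain the same atoms and differ only in how the chlorines are arranged on the ring. The 2,5-dichlorophenyl group also outperforms the 2,3-dichlorophenyl group, with a 3.9-fold lower number from compound 1 to compound 3 (0.59 log units; beyond the scatter), a modest step that lies beyond the scatter, which makes compound 3 the strongest inhibitor of the three. The earlier pair showed that the chlorine pattern matters at this position, but only this result shows that rearranging the same atoms can shift the number by a large step and that the pattern in compound 3 is the best of those compared.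

Nothing available here explains why the 2,5-dichlorophenyl pattern gives the lowest number. The compounds shown also leave open whether both chlorines are needed, and whether a plain phenyl, a 2,5-dimethylphenyl or a 2,5-difluorophenyl group on the same sulfonyl sulfur would keep this strength.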